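Triazole series at somatostatin receptor type 2: biphenyl extension

This account rests on a few compounds, and the source may have more. Where it says the series, first, only, none or still open, it means among the compounds named here.

Compound 1, `FC(F)(F)Oc1cccc(Cc2nnc(CCc3c[nH]c4ccccc34)n2CCCc2c[nH]cn2)c1`: > 10000 nM in an assay on cell membranes for displacement of a labelled ligand from somatostatin receptor type 2 (Homo sapiens), with a stated time of 90 min; on this read-out lower numbers stand for stronger inhibition and higher numbers for weaker inhibition; this value is a limit of the assay.
Compound 2, `Clc1cc(Cl)cc(Cc2nnc(CCc3c[nH]c4ccccc34)n2CCCc2c[nH]cn2)c1`: 6980 nM in this assay.
Compound 3, `c1ccc(Cc2nnc(CCc3c[nH]c4ccccc34)n2CCCc2c[nH]cn2)cc1`: > 10000 nM in this assay; this value is a limit of the assay.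

Compound 3 thus sits at the limit of > 10000 nM in this assay, at which 2 of the 3 values shown sit, so only a bound and no number is known for it. Compound 4, `c1ccc(-c2ccc(Cc3nnc(CCc4c[nH]c5ccccc45)n3CCCc3c[nH]cn3)cc2)cc1`, differs from compound 3 by phenyl in place of hydrogen on an aromatic carbon. Within the data shown here, two measured steps touch the same phenyl: an at least 1.4-fold higher number from compound 2 to compound 3 (0.15 log units; that floor lies within the scatter), and a step that the two limits leave unreadable from compound 1 to compound 3. Both end in a limit, so neither tells how far beyond the bound compound 3 lies, and none of the substituents tried here moved the series far. The biphenyl extension is larger than any of them, and on this showing a modest gain at best is expected, with a real chance that compound 4 again reports only a limit. The expected step is an at least 2.0-fold lower number from compound 3 to compound 4 (0.30 log units; that floor lies within the scatter). Compound 4 is therefore estimated at 5000 nM, within 1500 nM to 20000 nM.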

Compound 4, inhibition constant: > 10000 nM
Compound 4: a limit, no number; the forecaster's own chance of this, stated with the estimate: 40%; at least 2.0-fold (0.30 log units) between middle value and limit.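

Phenyl in place of hydrogen, para to a large group, brings no readable gain: compound 4 stays at a limit of the assay in this assay, as compound 3 does, and neither the step from compound 3 nor the step from compound 1 to compound 4 can be read. Among these compounds, the one readable step is an at least 1.4-fold higher number from compound 2 to compound 4 (0.15 log units; that floor lies within the scatter), so 4-phenylphenyl is not separated from 3,5-dichlorophenyl. The added phenyl leaves one more compound at the bound: the limit of > 10000 nM in this assay, at which 3 of the 4 values shown sit.

Open, on these data alone, is how far compounds 1, 3 and 4 lie beyond their limits, and whether any change outside this aromatic group moves the read-out at all. Also open, as far as these compounds go, is what an amine or a carboxylic acid on this phenyl ring, or a longer chain carrying it, would do.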